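Amine variation on the saturated ring carbon of compound 3

A few compounds are considered here, and "the series" means these few. Any claim that something is new, unique, unknown or untested is made for them only; others in the source may bear on it.

Of the compounds shown here, three have numbers so far. Compound 1 `CC(C)N(CCNC(=O)[C@H]1C[C@@H]1c1ccccc1)C(C)C` gives 63.1 nM in an assay on CHO cells for displacement of a labelled ligand from Sigma non-opioid intracellular receptor 1 (Homo sapiens), with a stated time of 180 min; a higher number here means a weaker inhibitor, a lower number a stronger inhibitor. Compound 2 `CN(C)CC(C)(C)CNC(=O)[C@H]1C[C@@H]1c1ccccc1` gives 398 nM in this assay, the highest number of the three. Compound 3 `O=C([C@H]1C[C@@H]1c1ccc(F)cc1)N1CCC(N2CCCCC2)CC1` gives 100 nM in this assay, the second highest number; its gap to compound 1 lies within the scatter, so the two cannot be placed in order, while compound 2 shows a higher number than compound 3 by a margin beyond the scatter.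

Compound 4 `O=C([C@H]1C[C@@H]1c1ccc(F)cc1)N1CCC(CNCC2CCCCC2)CC1` has not yet been measured in this assay. Relative to compound 3 the change is ((cyclohexylmethyl)amino)methyl in place of piperidin-1-yl on a saturated ring carbon. Within the data shown here, no step between two measured compounds alters a group on that ring carbon, so nothing in the numbers so far calibrates this change directly; the shared core and the amide are kept throughout.

The step from compound 3 to compound 4 is expected to be modest, towards a lower number, and is estimated as a 2.5-fold lower number from compound 3 to compound 4 (0.40 log units; beyond the scatter), which may or may not clear the scatter. On that basis compound 4 is estimated to give 40 nM in this assay, with a range from 8 nM to 200 nM.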

Compound 4, inhibition constant: 79.4 nM
Compound 4: the middle estimate sits 2.0-fold (0.30 log units) below what was measured, within the range that was stated.
By their numbers in this assay, from the lowest: compounds 1, 4 and 3 (each within the scatter of the next); then compound 2.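

In this assay, among these compounds, ((cyclohexylmethyl)amino)methyl in place of piperidin-1-yl on the saturated ring carbon gives a 1.3-fold lower number from compound 3 to compound 4 (0.10 log units; within the scatter), the first reading of any change at this position. The entering group is larger by its heavy-atom count, swaps the six-membered ring with a nitrogen for a ring of carbon only, and brings a hydrogen-bond donor, yet compound 3 and compound 4 cannot be placed in order, so this position accepts this particular exchange without a difference that can be read. No measurement shown bears on why the two numbers lie so close.

Among the compounds shown here, the single step does not separate the contributions of the entering group's parts, so a methyl group on the amine nitrogen of ((cyclohexylmethyl)amino)methyl would test the hydrogen-bond donor on its own, and a benzyl group in place of the cyclohexylmethyl would test the carbon ring. As far as these compounds go, it also remains open how a shorter or longer chain between the amine nitrogen and the saturated ring carbon, or a morpholine in place of the piperidine, would read in this assay.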